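The source may report more compounds than this note shows. Statements on the series, on what has been measured and on what is new or still open speak of the compounds shown alone.

Working notes on the series. Compound 1 `Cc1c(O)c(=O)ccn1CC(=O)N/N=C1\C(=O)N(CC(=O)Nc2ccccc2Cl)c2ccccc21` gives in a functional assay on MCF7 cells (Homo sapiens) for cytotoxicity, read by MTT assay, with a stated time of 48 h (a lower number here means that less compound is needed, a higher number that more compound is needed for the effect), a value of 46400 nM. Compound 2 `Cc1cccc(NC(=O)CN2C(=O)/C(=N\NC(=O)Cn3ccc(=O)c(O)c3C)c3ccccc32)c1C` gives in this assay a value of 51900 nM, and compound 3 `Cc1c(O)c(=O)ccn1CC(=O)N/N=C1\C(=O)N(CC(=O)Nc2ccc(Cl)cc2Cl)c2ccccc21` gives in this assay a value of 43200 nM. The three numbers sit together: a 1.1-fold lower number from compound 1 to compound 3 (0.03 log units; within the scatter) and a 1.2-fold lower number from compound 2 to compound 3 (0.08 log units; within the scatter), so compound 3 stands with compounds 1 and 2 within the scatter, and no order among them can be read.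

Compound 4 `Cc1c(O)c(=O)ccn1CC(=O)N/N=C1\C(=O)N(CC(=O)Nc2cc(Cl)cc(Cl)c2)c2ccccc21` is not yet measured. It differs from compound 3 by 3,5-dichlorophenyl in place of 2,4-dichlorophenyl on an amide-type nitrogen. The measured steps that bear on this are the swaps of the aryl group on the same amide-type nitrogen: a 1.1-fold higher number from compound 1 to compound 2 (0.05 log units; within the scatter) and a 1.2-fold lower number from compound 2 to compound 3 (0.08 log units; within the scatter), both within the scatter; a 1.1-fold lower number from compound 1 to compound 3 (0.03 log units; within the scatter) is likewise within the scatter. Every change so far at this position has left the number essentially unchanged, so no step beyond the scatter is expected from compound 3 to compound 4 in this assay; the expected step is a 1.0-fold higher number from compound 3 to compound 4 (0.02 log units; within the scatter). Compound 4 is therefore estimated at 45000 nM in this assay, with a range from 22000 nM to 92000 nM.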

Compound 4, half-maximal effective concentration: 35100 nM
Beside the measured number, compound 4's estimate is 1.3-fold (0.11 log units) above it; the measured number falls inside the stated range.
By their numbers in this assay, from the lowest: compounds 4, 3, 1 and 2 (each within the scatter of the next).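

Within the data shown here, exchanging 2,4-dichlorophenyl for 3,5-dichlorophenyl on the amide-type nitrogen, with the same atoms joined differently, gives a 1.2-fold lower number from compound 3 to compound 4 (0.09 log units; within the scatter) in this assay, so this rearrangement of the two chlorines is the first change at this position that keeps the atoms fixed, and it stays within the scatter. The swaps from the other aryl groups also stay within the scatter, with a 1.3-fold lower number from compound 1 to compound 4 (0.12 log units; within the scatter) and a 1.5-fold lower number from compound 2 to compound 4 (0.17 log units; within the scatter), so all four compounds remain one flat group in this assay and the place of the substituents on this phenyl ring shows no effect here. Nothing measured in the series offers an explanation for this flatness.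

Open, as far as these compounds go, is whether an aryl group carrying an amine or a carboxylic acid, or a longer chain in place of the aryl group, would move the number beyond the scatter. Also open, from the compounds shown here alone, is whether changes to the shared core would do so where changes to this aryl group have not.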